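The compounds below may be only part of what the source reports. "The series", "measured", "known", "first", "only" and "open" are said of these compounds alone.

Measured compounds:
- compound 1, `Cc1cc(-c2ccc(F)nc2F)nn(Cc2ccc(Cl)cc2)c1=O`: 83800 nM
- compound 2, `COc1cc(-c2ccc(F)nc2F)nn(Cc2ccc(Cl)cc2)c1=O`: 92200 nM

In an ADME assay on HepG2 2.2.15 cells (Homo sapiens) for cytotoxicity, read by MTT assay, with a stated time of 8 days (a higher number here means that more compound is tolerated, a lower number that less compound is tolerated), compound 1 gives 83800 nM, the lowest of the two numbers seen here. For the measured compounds named here, its only neighbour is compound 2, which gives 92200 nM; the step of a 1.1-fold higher number from compound 1 to compound 2 (0.04 log units; within the scatter) is small, so the two compounds cannot be told apart on this read-out.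

Compound 3, `Cc1c(-c2ccc(F)nc2F)nn(Cc2ccc(Cl)cc2)c(=O)c1C`, has not yet been measured in this assay. It differs from compound 1 by methyl in place of hydrogen on an aromatic carbon.

Going by the values given here, no measured step concerns a methyl entering in place of hydrogen; the one step that exists, from methyl to methoxy, was within the scatter. It shows that a small change on the shared core left the tolerated concentration essentially unchanged, but it does not speak directly to the present change. Without a closer precedent, the expectation is a step from compound 1 to compound 3 of no more than the scatter, a 1.0-fold lower number from compound 1 to compound 3 (0.02 log units; within the scatter), in no particular direction. Compound 3 is therefore estimated at 80000 nM, with a range from 40000 nM to 160000 nM.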

Compound 3, half-maximal cytotoxic concentration: 52900 nM
For compound 3 the middle estimate is 1.5-fold (0.18 log units) above the measured one; the range from low to high includes it.
By their numbers in this assay, from the lowest: compounds 3, 1 and 2 (each within the scatter of the next).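

In this assay, adding a methyl on this aromatic carbon, ortho to a 2,6-difluoropyridin-3-yl group and ortho to a methyl group, gives a 1.6-fold lower number from compound 1 to compound 3 (0.20 log units; within the scatter), so the added methyl cannot be told apart from repeat-to-repeat scatter on this read-out. The earlier step, a 1.1-fold higher number from compound 1 to compound 2 (0.04 log units; within the scatter), concerned a different place on the shared core, so these compounds now show that neither of the two places, changed in these small ways, moves the tolerated concentration beyond the scatter. No available measurement bears on the reason for the number seen with compound 3.

The compounds shown leave open whether something larger or of a different kind on this carbon, such as an ethyl group, a longer chain, an amine or a carboxylic acid, would also stay within the scatter. They also leave open how a methyl would behave here without the methyl group already present on the neighbouring position of the shared core, and the comparison rests on this assay alone.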